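Opening the ring of compound 2

This account rests on a few compounds, and the source may have more. Where it says the series, first, only, none or still open, it means among the compounds named here.

Of the compounds shown here, three sharing one core have so far been measured in a physicochemical assay for solubility, in phosphate buffer, at pH 7.4; a lower number here means a less soluble compound, a higher number a more soluble compound. Compound 1 (`Nc1nc(-c2cccc(OC(F)(F)F)c2)cc(=O)[nH]1`) gives 330000 nM, and compound 3 (`N#Cc1cc(-c2cc(=O)[nH]c(N)n2)cc(C(F)(F)F)c1`) gives 430000 nM. Compound 2 (`Nc1nc(-c2ccc(OCC3CCOC3)cc2)cc(=O)[nH]1`) gives 58000 nM, the lowest of the three numbers, and its gaps to both of the others lie beyond the scatter of repeated measurements.

Compound 4 (`Nc1nc(-c2ccc(OCCCCO)cc2)cc(=O)[nH]1`) has not been measured yet. It differs from compound 2 in one place: 3-hydroxypropyl in place of oxolan-3-yl on a saturated chain carbon bound to an oxygen on an aromatic ring. Read one bond further out, (oxolan-3-yl)methoxy becomes 4-hydroxybutoxy. The entering 3-hydroxypropyl has no ring and brings a hydrogen-bond donor, which oxolan-3-yl does not have.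

Within the data shown here, no two measured compounds differ in just one place, so the data offer no direct precedent for this change, and the estimate below is uncertain. Compound 1 and compound 3 carry different groups and can only show the range of numbers seen so far. A modest rise in this assay is expected from the structural change, starting from compound 2 at 58000 nM. The expected upward move is a 2.2-fold higher number from compound 2 to compound 4 (0.35 log units; beyond the scatter). For compound 4, the estimated solubility is 130000 nM, within an expected range of 50000 nM to 350000 nM.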

Compound 4, solubility: 95000 nM
For compound 4 the middle estimate is 1.4-fold (0.14 log units) above the measured one; measured number inside the range.
By their numbers in this assay, from the lowest: compounds 2 and 4 (each within the scatter of the next); then compounds 1 and 3 (each within the scatter of the next).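

This is the only pair shown that differs in one place, and it gives a first direct reading at this position: 3-hydroxypropyl in place of oxolan-3-yl gives a 1.6-fold higher number from compound 2 to compound 4 (0.21 log units; within the scatter) in this assay for this pair. Read one bond further out, the change swaps (oxolan-3-yl)methoxy for 4-hydroxybutoxy, removing a ring and adding a hydrogen-bond donor, yet the two compounds cannot be told apart in this measurement, since their difference is no larger than that expected between repeats of a single compound. No separate measurement shown here offers an explanation for this result.

This single step combines the loss of the ring with the gain of the hydrogen-bond donor, and the compounds shown do not separate the two differences. From the compounds shown here alone, it also remains open whether an amine or a carboxylic acid in place of the hydroxy group, or a longer chain carrying the same hydroxy group, would give a step beyond the scatter in this assay at this position.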